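This account rests on a few compounds, and the source may have more. Where it says the series, first, only, none or still open, it means among the compounds named here.

Of the compounds shown here, two have been measured in a functional assay for activation of Alpha-1D adrenergic receptor (Homo sapiens), read by calcium flux; a lower number here means that less compound is needed, a higher number that more compound is needed for the effect. Compound 1 `CCN(CC)C(=O)c1ccccc1OCC1=NCCN1` carries a diethylamide on the shared core. For compound 1 the assay reports only a limit, < 5020 nM, and not a number. Compound 2 `c1cnc(-c2ccccc2OCC2=NCCN2)nc1` carries a pyrimidin-2-yl group on that core instead. On these data alone, for compound 2 this assay again gives only a limit, < 100000 nM, so where it truly stands remains open. The two limits are different ones: the limit of < 5020 nM in this assay, at which 1 of the 2 values shown sits, and (the limit of < 100000 nM in this assay, at which 1 of the 2 values shown sits). For the measured compounds named here, no step between two measured compounds can be traced, since none of them differ in only one place.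

Compound 3 `c1c[nH]c(-c2ccccc2OCC2=NCCN2)c1` has not yet been measured. Its change from compound 2 is 1H-pyrrol-2-yl in place of pyrimidin-2-yl on an aromatic carbon. Because compound 2 stands only at a limit, < 100000 nM, the direction of the step to compound 3 cannot be fixed from the data. Compound 3 is expected to give about 3000 nM in this assay, with a likely range from 300 nM to 30000 nM. The step this estimate implies, a step that the limit leaves unreadable from compound 2 to compound 3, is measured against a limit and is expected to carry the uncertainty of that limit.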

Compound 3, half-maximal effective concentration: 6.31 nM
Estimate against measurement, compound 3: 480-fold (2.68 log units) above; measured number below the stated range.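

For the compounds shown here, the change from compound 2 to compound 3 gives no step that can be read in this assay. This is because compound 2 has only a limit and not a number: the limit of < 100000 nM in this assay, at which 1 of the 3 values shown sits. What the compounds shown leave open is where compound 2 truly stands, and so how large the change from pyrimidin-2-yl to 1H-pyrrol-2-yl is.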